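The source may report more compounds than this note shows. Statements on the series, on what has been measured and on what is new or still open speak of the compounds shown alone.

Working notes on the series

Compound 1 `O=C1NC[C@@H](c2c[nH]c3cc(Br)ccc23)N=C1c1c[nH]c2ccccc12` and compound 2 `O=C1NC[C@@H](c2c[nH]c3ccccc23)N=C1c1c[nH]c2ccccc12` differ by one change, (bromo in place of hydrogen on an aromatic carbon). In an ADME assay on A549 cells (Homo sapiens) for cytotoxicity (on this read-out lower numbers stand for an effect already at smaller amounts and higher numbers for an effect only at larger amounts of compound), compound 2 gives 11.7 ug/mL. In this assay compound 1 gives 3.71 ug/mL. The measured step is a 3.2-fold lower number from compound 2 to compound 1 (0.50 log units; beyond the scatter).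

Compound 3 `O=C1NC[C@@H](c2c[nH]c3ccccc23)N[C@H]1c1c[nH]c2ccccc12` carries a different core; how its core differs from that of compound 2 is not broken down here. For compound 3 in this assay only a limit is known, > 10 ug/mL, and this sits at the limit of > 10 ug/mL in this assay, at which 1 of the 3 values shown sits.

Compound 4 `O=C1NC[C@@H](c2c[nH]c3cc(Br)ccc23)N[C@H]1c1c[nH]c2ccccc12` is not yet measured in this assay. It stands to compound 3 as compound 1 stands to compound 2: the change is bromo in place of hydrogen on an aromatic carbon, described in the same words at the same place, so it is the same change, recurring among the compounds shown.

For this assay the expected step is an at least 2.0-fold lower number from compound 3 to compound 4 (0.30 log units; that floor lies within the scatter), resting on the size of a 3.2-fold lower number from compound 2 to compound 1 (0.50 log units; beyond the scatter) applied to the limit that compound 3 shows, > 10 ug/mL. The estimate for compound 4 in this assay is therefore 5 ug/mL, with a likely range from 2 ug/mL to 15 ug/mL.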

Compound 4, concentration for half-maximal effect: 4.2 ug/mL
Compound 4: the middle estimate sits 1.2-fold (0.08 log units) above what was measured; measured number inside the range.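

The bromo change carries over in direction: in this assay, the core of compound 3 shows an at least 2.3-fold lower number from compound 3 to compound 4 (0.37 log units; beyond the scatter), so both cores shown move the same way on this read-out. For compound 3, the value of > 10 ug/mL is a limit of the assay and not a number, so this step gives only a floor for the size of the change. The two cores therefore support a shared direction but do not establish an equal size, and two pairs say nothing about cores beyond those shown: the same change on two cores in this assay, a 3.2-fold lower number (0.50 log units; beyond the scatter) from compound 2 to compound 1 and an at least 2.3-fold lower number (0.37 log units; beyond the scatter) from compound 3 to compound 4; the limit leaves it open whether they differ.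

The compounds shown carry only bromo in place of hydrogen, at a single place on a six-membered aromatic ring of carbon only, so it remains open whether chloro, methoxy, an amine or a carboxylic acid at that place would go with a similar step. Going by these compounds, it also remains open whether the bromo step would hold in this assay on any further core.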